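The source may report more compounds than this note shows. Statements on the series, on what has been measured and on what is new or still open speak of the compounds shown alone.

Cytotoxicity in the series is followed in an ADME assay on NCM460 cells (Homo sapiens) for cytotoxicity, read by MTT assay, with a stated time of 72 h; on this read-out higher numbers stand for weaker inhibition and lower numbers for stronger inhibition. Compound 1 `Cc1ccc(N2C(=O)C/C(=C\c3cccc(C(=O)Nc4cccc(F)c4)c3)C2=O)cc1` returns only the assay limit there, > 100000 nM. Compound 2 `Cc1ccc(NC(=O)c2cccc(/C=C3\CC(=O)N(c4ccccc4)C3=O)c2)cc1C` likewise returns only a limit in this assay, > 100000 nM. Both values shown thus sit at the same point, (the limit of > 100000 nM in this assay, at which 2 of the 2 values shown sit), so compound 2 stands at the ceiling of what this assay reports, with no number to rank it by.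

Compound 3 `COc1ccc(NC(=O)c2cccc(/C=C3\CC(=O)N(c4ccccc4)C3=O)c2)c(C)c1` carries 4-methoxy-2-methylphenyl in place of 3,4-dimethylphenyl on an amide-type nitrogen. The amide-type nitrogen and the remainder of the shared core are kept. Among the compounds with values here, no measured step between compounds sets the size of such a change in this assay, so no direction is expected beyond the scatter, and the step from compound 2 to compound 3 is expected to be a step that the limit leaves unreadable from compound 2 to compound 3. Compound 3 is therefore expected at about 150000 nM in this assay, in a range of 60000 nM to 400000 nM, most likely again only a limit.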

Compound 3, half-maximal inhibitory concentration: > 100000 nM
Compound 3: only a limit was reported; the forecaster's own chance of this, stated with the estimate: 80%; the middle value lies beyond the limit too.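

In this assay compound 3 returns only a limit, > 100000 nM. No step from compound 2 to compound 3 can be read: the limit of > 100000 nM in this assay, at which 3 of the 3 values shown sit.

The compounds shown leave open whether 4-methoxy-2-methylphenyl in place of 3,4-dimethylphenyl changes the read-out at all, and whether any of them has a numerical value in this assay.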